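Trifluoromethoxyphenyl in place of dichlorophenyl in compound 3

The compounds below may be only part of what the source reports. "The series", "measured", "known", "first", "only" and "open" are said of these compounds alone.

Measured compounds:
compound 1, `COc1cc2c(Oc3ccc(NC(=O)N/N=C/c4ccc(F)cc4Cl)cc3F)ccnc2cc1OCCCN1CCCCC1`: 260 nM
compound 2, `COc1cc2c(Oc3ccc(NC(=O)N/N=C/c4ccc(Cl)cc4Cl)cc3F)ccnc2cc1OCCCN1CCCCC1`: 370 nM

In a functional assay on HT-29 cells (Homo sapiens) for cytotoxicity, read by MTT assay, with a stated time of 72 h (a lower number here means a stronger inhibitor, a higher number a weaker inhibitor), compound 1 gives 260 nM and compound 2 gives 370 nM. For the measured compounds named here, compound 2 holds the highest of the two numbers, with compound 1 nearest; the only measured step, a 1.4-fold higher number from compound 1 to compound 2 (0.15 log units; within the scatter), is within the scatter. Compound 3, `COc1cc2c(Oc3ccc(NC(=O)N/N=C/c4ccc(OC(F)(F)F)cc4)cc3F)ccnc2cc1OCCCN1CCCCC1`, differs from compound 2 in one place: 4-(trifluoromethoxy)phenyl in place of 2,4-dichlorophenyl on a carbon with a double bond to nitrogen. Going by the values given here, that one measured step exchanged a single halogen on an aromatic carbon and left the rest of the ring unchanged, whereas the change to compound 3 replaces the whole substituted ring, so no measured step bears directly on it. The expectation is therefore a step of a 1.1-fold higher number from compound 2 to compound 3 (0.03 log units; within the scatter), with no movement beyond the scatter assumed but a wide range allowed. Compound 3 is estimated at 400 nM, between 150 nM and 1100 nM.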

Compound 3, half-maximal inhibitory concentration: 510 nM
Compound 3: the middle estimate sits 1.3-fold (0.11 log units) below what was measured; the range from low to high includes it.
By their numbers in this assay, from the lowest: compounds 1, 2 and 3 (each within the scatter of the next).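

In this assay, the group on the carbon with a double bond to nitrogen was replaced as a whole ring rather than by a single halogen, and the steps stayed within the scatter: a 1.4-fold higher number from compound 2 to compound 3 (0.14 log units; within the scatter), and a 2.0-fold higher number from compound 1 to compound 3 (0.29 log units; within the scatter). At this position, therefore, these compounds do not separate, even though 4-(trifluoromethoxy)phenyl brings one hydrogen-bond acceptor where 2,4-dichlorophenyl has none. No separate measurement bears on why the number stays within the scatter across this exchange.

The compounds shown leave open whether an amine or a carboxylic acid on this ring, or a longer chain in place of the ring, would move the number beyond the scatter. From the compounds shown here alone, they also share one core, so it remains unknown whether the same exchange would behave alike on a different core.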